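Compound 3: phenyl in place of chloro

The source may report more compounds than this note shows. Statements on the series, on what has been measured and on what is new or still open speak of the compounds shown alone.

In a functional assay on MCF7 cells (Homo sapiens), read by colorimetric assay, with a stated time of 96 h (on this read-out lower numbers stand for stronger inhibition and higher numbers for weaker inhibition), the measured compounds give:
- Compound 1 `OC[C@@H](O)[C@H]1O[C@@H](n2cnc3c(Cl)ncnc32)[C@H](O)[C@@H]1O` gives > 100000 nM (a limit)
- Compound 2 `OC[C@@H](O)[C@H]1O[C@@H](n2cnc3c(Cl)nc(Cl)nc32)[C@H](O)[C@@H]1O` gives 54200 nM as a number

Compound 1 gives > 100000 nM as a limit and not a number. Compound 3 `OC[C@@H](O)[C@H]1O[C@@H](n2cnc3c(-c4ccccc4)ncnc32)[C@H](O)[C@@H]1O` differs from it by phenyl in place of chloro on an aromatic carbon. Among the measured compounds shown here, the one measured step shows an at least 1.8-fold lower number from compound 1 to compound 2 (0.26 log units; that floor lies within the scatter) for chloro in place of hydrogen on an aromatic carbon, a different change, so only weak guidance follows for this assay and no firm shift beyond the scatter is expected. The expected at least 1.6-fold lower number from compound 1 to compound 3 (0.22 log units; that floor lies within the scatter) is small and tentatively towards a lower number. Compound 3 is expected near 60000 nM with an estimated range from 20000 nM to 100000 nM for now.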

Compound 3, half-maximal inhibitory concentration: > 100000 nM
Compound 3 was reported as a limit; the forecaster's own chance of this, stated with the estimate: 45%; at least 1.6-fold (0.22 log units) between middle value and limit.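

In this assay, compound 1 and compound 3 are both reported as limits and not numbers, so no step between them can be read because both sit at the same limit: the limit of > 100000 nM in this assay, at which 2 of the 3 values shown sit.

The compounds shown leave open how far phenyl in place of chloro shifts the read-out.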